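Compound 4 estimated from three limit values

A few compounds are considered here, and "the series" means these few. Any claim that something is new, unique, unknown or untested is made for them only; others in the source may bear on it.

Compound 1 `Cc1ccccc1-n1nncc1CN1C(=O)C2(C(C#N)=C(N)Oc3c(N)cc4nc5ccccc5nc4c32)c2ccccc21` gives > 50000 nM in an ADME assay on HUVEC cells (Homo sapiens) for antiproliferative activity, read by MTT assay, with a stated time of 48 h; a higher number here means a weaker inhibitor, a lower number a stronger inhibitor.
Compound 2 `N#CC1=C(N)Oc2c(N)cc3nc4ccccc4nc3c2C12C(=O)N(Cc1cnnn1-c1ccc(F)cc1)c1ccccc12` gives > 50000 nM in this assay.
Compound 3 `N#CC1=C(N)Oc2c(N)cc3nc4ccccc4nc3c2C12C(=O)N(Cc1cnnn1-c1ccc(Cl)cc1)c1ccccc12` gives > 50000 nM in this assay.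

The value of compound 1 is a limit, not a number. The value of compound 2 is likewise a limit. The value of compound 3 is a limit as well, so compound 3 stands only at the limit, and the two other values shown are limits too. Compound 4 `N#CC1=C(N)Oc2c(N)cc3nc4ccccc4nc3c2C12C(=O)N(Cc1cnnn1-c1cccc(Br)c1)c1ccccc12` differs from compound 3 by 3-bromophenyl in place of 4-chlorophenyl on an aromatic nitrogen. The measured steps that bear on it, a step that the two limits leave unreadable from compound 1 to compound 2, a step that the two limits leave unreadable from compound 1 to compound 3 and a step that the two limits leave unreadable from compound 2 to compound 3, are all unreadable because of the limit of > 50000 nM in this assay, at which 3 of the 3 values shown sit. No size or direction can be read for a change of the aryl group on the aromatic nitrogen, so no step beyond the scatter is expected and a further limit is the likeliest outcome. Compound 4 is expected to give 60000 nM, within 30000 nM to 200000 nM, an estimated step that the limit leaves unreadable from compound 3 to compound 4.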

Compound 4, half-maximal inhibitory concentration: > 50000 nM
Compound 4: no number, only a limit; the forecaster's own chance of this, stated with the estimate: 85%; the middle value is on the limit's open side.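

Compound 4 also gives only a limit, so its steps from compound 1, compound 2 and compound 3 in this assay cannot be read: the limit of > 50000 nM in this assay, at which 4 of the 4 values shown sit. As far as these compounds go, the size and direction of any effect of changing the aryl group on the aromatic nitrogen in this assay remain open.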